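One Chloro Substitution, Carried Onto a Second Core

The compounds below may be only part of what the source reports. "The series", "measured", "known", "first", "only" and "open" are said of these compounds alone.

Measured so far, in an assay on isolated protein for inhibition of Fatty-acid amide hydrolase 1 (Homo sapiens), read by fluorescence, with a stated time of 30 min; a higher number here means a weaker inhibitor, a lower number a stronger inhibitor:
- compound 1, `CCOC(=O)c1cc(-c2cccc(OC(=O)NC3CCCCC3)c2)nn1-c1ccccc1`, gives 539 nM
- compound 2, `CCOC(=O)c1cc(-c2cccc(OC(=O)NC3CCCCC3)c2)nn1-c1ccc(Cl)cc1`, gives 353 nM
- compound 3, `CCOC(=O)c1cc(-c2ccc(OC(=O)NC3CCCCC3)cc2)nn1-c1ccccc1`, gives 592 nM

The three measured compounds sit close together. From compound 1 to compound 2 the change is chloro in place of hydrogen on an aromatic carbon, and the step it made was a 1.5-fold lower number from compound 1 to compound 2 (0.18 log units; within the scatter). Compound 3 shares its atoms with compound 1 but joins them differently; the difference between the two cores is not broken down here. Its value lies nearest to that of compound 1 and furthest from that of compound 2, yet both gaps fall within the scatter, so no order among the three can be read from them.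

Compound 4, `CCOC(=O)c1cc(-c2ccc(OC(=O)NC3CCCCC3)cc2)nn1-c1ccc(Cl)cc1`, has not yet been measured. It differs from compound 3 by chloro in place of hydrogen on an aromatic carbon, the same change, at the same place, that separates compound 2 from compound 1. For the measured compounds named here, only this one earlier example of the change is available, and it barely moved the number, so the expectation for compound 4 rests on that single step and on the value of compound 3. Compound 4 is expected to show a step of a 1.5-fold lower number from compound 3 to compound 4 (0.17 log units; within the scatter), mirroring the earlier step because of a 1.5-fold lower number from compound 1 to compound 2 (0.18 log units; within the scatter). Compound 4 is therefore estimated at 400 nM, with a likely range from 200 nM to 800 nM.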

Compound 4, half-maximal inhibitory concentration: 586 nM
The estimate for compound 4 lay 1.5-fold (0.17 log units) below the measured number; low and high end bracket the measured number.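

In this assay the change from phenyl to 4-chlorophenyl on the core of compound 3 gave a 1.0-fold lower number from compound 3 to compound 4 (0.00 log units; within the scatter) and so leaves compound 3 and compound 4 indistinguishable. Neither this step nor the earlier one on the core of compound 1 can be told from the scatter, so the series does not show that the chloro group affects the number on either core, and one pair on each of two cores supports no general rule. What it does show is that the change reads alike on both cores as far as this assay can resolve, with no sign that the core alters its outcome: the same change on two cores in this assay, a 1.5-fold lower number (0.18 log units; within the scatter) from compound 1 to compound 2 and a 1.0-fold lower number (0.00 log units; within the scatter) from compound 3 to compound 4, 1.5-fold (0.18 log units) apart, within the scatter of two such steps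

The compounds shown leave open whether a different group in place of the chloro, such as a methoxy group, an amine or a carboxylic acid, would give a step that stands clear of the scatter on either core. They also leave open whether the chloro change would still read alike on the two cores if a carboxylic acid took the place of the ester.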